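The source may hold more compounds than are shown below. What is called first, only, known or untested is meant among the compounds shown, and "the series" means these compounds.

Measured so far in an ADME assay on GES1 cells (Homo sapiens) for inhibition, read by MTT assay, with a stated time of 72 h; a lower number here means a stronger inhibitor, a higher number a weaker inhibitor:
Compound 1 `COc1ccc(Cn2ccc(Nc3cc(C)nc4nc(SCc5ccc(Br)cc5)nn34)n2)cc1` with > 50000 nM (a limit)
Compound 2 `Cc1ccc(Cn2ccc(Nc3cc(C)nc4nc(SCc5ccc(Br)cc5)nn34)n2)cc1` with > 50000 nM (a limit)

Compound 2 stands at > 50000 nM in this assay and this is a limit of the assay, not a number. The record so far reads the limit of > 50000 nM in this assay, at which 2 of the 2 values shown sit, and no measured number exists yet.

The next compound is compound 3 `Cc1cc(Nc2ccn(Cc3ccc(C(F)(F)F)cc3)n2)n2nc(SCc3ccc(Br)cc3)nc2n1` and it has trifluoromethyl in place of methyl on an aromatic carbon of the six-membered aromatic ring of carbon only, para to a large group (trifluoromethyl in place of methyl on an aromatic carbon).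

Going by the values given here, only one measured step bears on this change. It is a step that the two limits leave unreadable from compound 1 to compound 2 and it is likewise a swap of one group on an aromatic carbon, but it offers no size to carry over. No step beyond the scatter is therefore expected in this assay and another limit is the likeliest report. The expected size is a number no higher from compound 2 to compound 3 (the limit leaves the size open) on this estimate. For compound 3 the estimated value is 50000 nM with an expected range from 20000 nM to 80000 nM on this reading.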

Compound 3, half-maximal inhibitory concentration: 30200 nM
Beside the measured number, compound 3's estimate is 1.7-fold (0.22 log units) above it, within the range that was stated.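

In this assay, going by these compounds alone, compound 3, which carries the 4-(trifluoromethyl)benzyl group, gives 30200 nM, the first value at this position that is a number and not a limit of the assay. Read against the earlier compounds, trifluoromethyl in place of methyl gives an at least 1.6-fold lower number from compound 2 to compound 3 (0.21 log units; that floor lies within the scatter), and trifluoromethyl in place of methoxy gives an at least 1.6-fold lower number from compound 1 to compound 3 (0.21 log units; that floor lies within the scatter); each is only a floor, so neither change is shown to exceed the scatter, though the true steps could be larger. The step from compound 1 to compound 2 still cannot be read, and the other two values in the series remain limits: the limit of > 50000 nM in this assay, at which 2 of the 3 values shown sit.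

The compounds shown leave open how large the true steps from the two limits are, and whether the change at this place can move the number any further. They also leave open whether a nitrile, a chlorine atom, an amine or a carboxylic acid in place of trifluoromethyl would give a measured number or return the series to the limit.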